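Trading a methylated sulfonamide for a free one

A few compounds are considered here, and "the series" means these few. Any claim that something is new, unique, unknown or untested is made for them only; others in the source may bear on it.

Of the compounds shown here, three sharing one core have been tested in an assay on CHO cells for displacement of a labelled ligand from prostaglandin D2 receptor 2 (Homo sapiens), read by scintillation counting; a lower number here means a stronger inhibitor, a higher number a weaker inhibitor. Compound 1 `Cc1ccc(S(=O)(=O)N(C)CC(C)C)cc1C#Cc1cc(Cl)ccc1OCC(=O)O` gives 4.2 nM. Compound 2 `CNS(=O)(=O)c1ccc(C)c(C#Cc2cc(Cl)ccc2OCC(=O)O)c1` gives 10 nM, and compound 3 `Cc1ccc(S(=O)(=O)N(C)C(C)C)cc1C#Cc1cc(Cl)ccc1OCC(=O)O` gives 3.8 nM. Compound 3 has the lowest number of the three; against compound 1 the difference is a 1.1-fold lower number from compound 1 to compound 3 (0.04 log units; within the scatter), which says nothing either way, while against compound 2 it is a 2.6-fold lower number from compound 2 to compound 3 (0.42 log units; beyond the scatter).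

Compound 4 `Cc1ccc(S(=O)(=O)NC(C)(C)C)cc1C#Cc1cc(Cl)ccc1OCC(=O)O` has not yet been measured. It differs from compound 3 in a single place: (tert-butyl)amino in place of isopropyl(methyl)amino on a sulfonyl sulfur.

For the measured compounds named here, two measured steps bear on this change. Taking the alkyl group off the sulfonamide nitrogen and leaving a hydrogen gave a 2.4-fold higher number from compound 1 to compound 2 (0.38 log units; beyond the scatter), and the reverse, putting isopropyl in place of hydrogen, gave a 2.6-fold lower number from compound 2 to compound 3 (0.42 log units; beyond the scatter). Compound 4 likewise carries a hydrogen on that nitrogen, yet the tert-butyl group that remains holds the same atoms as before, joined differently, so the change is gentler than either of those steps. A modest rise in the number is therefore expected, smaller than the two steps just described.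

For compound 4 the expected step is a 1.6-fold higher number from compound 3 to compound 4 (0.20 log units; within the scatter). Compound 4 is accordingly estimated at 6 nM, with a range from 2.5 nM to 15 nM.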

Compound 4, inhibition constant: 5 nM
The estimate for compound 4 lay 1.2-fold (0.08 log units) above the measured number; low and high end bracket the measured number.
By their numbers in this assay, from the lowest: compounds 3, 1, 4 and 2 (each within the scatter of the next, the first and the last beyond it).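

Replacing isopropyl(methyl)amino with (tert-butyl)amino on the sulfonyl sulfur keeps the same atoms but adds one hydrogen-bond donor, and in this assay this gives a 1.3-fold higher number from compound 3 to compound 4 (0.12 log units; within the scatter) and the comparison with the isobutyl compound gives a 1.2-fold higher number from compound 1 to compound 4 (0.08 log units; within the scatter), so neither step separates the compounds. For the compounds shown here, until now compound 2 was the only compound with a hydrogen on the sulfonamide nitrogen, and its distance beyond the scatter from compound 1 and compound 3 could have made that hydrogen look like a cost, but compound 4 also carries this hydrogen and cannot be told apart from either of them. Exchanging methyl for tert-butyl on the nitrogen gives a 2.0-fold lower number from compound 2 to compound 4 (0.30 log units; within the scatter), so compound 4 cannot be told apart from compound 2 either, and across these four compounds the hydrogen alone does not decide the number.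

Still open, on these data alone, is how isopropylamino, which would keep the hydrogen and the isopropyl group together, would compare, and whether a chain ending in a hydroxyl or an amine, or a piperidine closing the nitrogen into a ring, would be tolerated at this position. Nothing available here accounts for why these numbers lie so close together.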